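Methoxycarbonyl in Place of Isopropyl on the Aryl Ring

The source may report more compounds than this note shows. Statements on the series, on what has been measured and on what is new or still open speak of the compounds shown alone.

compound 1 `CC(C)c1ccc(N2C(=O)C=CC2OCC(F)(F)F)cc1`: 9570 nM
compound 2 `O=C1C=CC(OCC(F)(F)F)N1c1cc(F)cc(F)c1`: 5000 nM
compound 3 `O=C1C=CC(OCC(F)(F)F)N1c1ccc(F)c(Cl)c1`: 7690 nM

Of the compounds shown here, three sharing one core have been measured in a functional assay on A549 cells (Homo sapiens) for inhibition; on this read-out lower numbers stand for stronger inhibition and higher numbers for weaker inhibition. Compound 1 gives the largest of the three numbers, yet its distance to compound 3 and to compound 2 each lies within the usual scatter, so the three cannot be told apart on this read-out. Compound 4 `COC(=O)c1ccc(N2C(=O)C=CC2OCC(F)(F)F)cc1` has not yet been measured. It differs from compound 1 in one place: methoxycarbonyl in place of isopropyl on an aromatic carbon. No comparable change has been measured between two known compounds, so the size of the coming step has to be guessed without a direct precedent. Since compound 1 sits close to compound 2 and compound 3 despite different aryl substituents, the expectation is a step no larger than the scatter, in either direction. Compound 4 is therefore expected to give about 8000 nM in this assay, within a range from 2500 nM to 25000 nM, which corresponds to an expected step of a 1.2-fold lower number from compound 1 to compound 4 (0.08 log units; within the scatter).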

Compound 4, half-maximal inhibitory concentration: 8170 nM
For compound 4 the middle estimate is 1.0-fold (0.01 log units) below the measured one, within the range that was stated.
By their numbers in this assay, from the lowest: compounds 2, 3, 4 and 1 (each within the scatter of the next).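

In this assay, methoxycarbonyl in place of isopropyl on an aromatic carbon, para to a large group, gives a 1.2-fold lower number from compound 1 to compound 4 (0.07 log units; within the scatter), so the two compounds cannot be told apart. For the compounds shown here, this is the first comparison in the set that differs in one place, which the earlier compounds could not provide. It shows that, on this read-out, this position accepts a group with hydrogen-bond acceptors and a double bond outside aromatic rings in place of isopropyl without a step beyond the scatter. No independent measurement bears on this result.

From the compounds shown here alone, whether an amine, a carboxylic acid or a longer chain at this carbon would give a step beyond the scatter remains open. Also open, going by these compounds, is whether methoxycarbonyl would give a similar step on the aryl rings of compound 2 and compound 3.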